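The source may hold more compounds than are shown below. What is called first, only, known or untested is meant among the compounds shown, and "the series" means these compounds.

Measured compounds:
- compound 1 `CC(C)(C)c1cc(NC(=O)Nc2cc(C(F)(F)F)cc(C(F)(F)F)c2)n(-c2ccccc2)n1`: 0 degrees C
- compound 2 `Cc1ccc(S(=O)(=O)NC(=O)Nc2cc(C(C)(C)C)nn2-c2ccccc2)cc1`: -0.3 degrees C
- compound 3 `COc1cccc(NC(=O)Nc2cc(C(C)(C)C)nn2-c2ccccc2)c1`: 3.6 degrees C

In an assay on isolated protein for inhibition of STE20-like serine/threonine-protein kinase (Homo sapiens), read by thermal shift assay, tested at 10 uM (on this read-out higher numbers stand for stronger stabilisation of the target against heat and lower numbers for weaker stabilisation of the target), compound 1 gives 0 degrees C. On the three numbers shown, compound 1 stands second highest; compound 2 lies within the scatter of it, while compound 3 sits higher by a margin beyond the scatter. Compound 4 `CC(C)(C)c1cc(NC(=O)Nc2cc(C(F)(F)F)cc(C(F)(F)F)c2)n(-c2ccc(Br)cc2)n1` differs from compound 1 in one place: bromo in place of hydrogen on an aromatic carbon. Going by the values given here, no measured pair covers this change, so nothing shows how a bromo at that place moves the melting-temperature shift. The step from compound 1 to compound 4 is therefore expected to be small, a number 0.40 degrees C higher from compound 1 to compound 4 (within the scatter), with no change beyond the scatter. For compound 4 the expected value is 0.4 degrees C, within -1 degrees C to 2 degrees C.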

Compound 4, shift of the target's melting temperature: 0.1 degrees C
The estimate for compound 4 lay 0.30 degrees C above the measured number; the measured number falls inside the stated range.
By their numbers in this assay, from the lowest: compounds 2, 1 and 4 (each within the scatter of the next); then compound 3.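

In this assay, going by these compounds alone, the change from phenyl to 4-bromophenyl gives a number 0.10 degrees C higher from compound 1 to compound 4 (within the scatter), the first measured pair at this place on the ring. Bromo in place of hydrogen therefore produces no shift beyond the scatter on the core of compound 1. No further data bear on the reason for this result. Still open, as far as these compounds go, is whether an amine or a carboxylic acid at this place would give a shift beyond the scatter. Also open, from the compounds shown here alone, is whether bromo would read the same way with the rest of compound 3 in place.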